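The compounds below may be only part of what the source reports. "The series", "measured", "known", "first", "only" and "open" are said of these compounds alone.

Compound 1 `C=C1CC[C@@H]2[C@](C)(CNCc3ccccc3)[C@H](O)CC[C@@]2(C)[C@@H]1/C=C/C1=CCOC1=O` and compound 2 `C=C1CC[C@@H]2[C@](C)(CNCc3ccc(OC)cc3)[C@H](O)CC[C@@]2(C)[C@@H]1/C=C/C1=CCOC1=O` share a core that carries a (benzylamino)methyl group on a saturated ring carbon. In a functional assay on BMMC cells (Mus musculus, strain C57BL/6) for inhibition, with stated times of 5 days and 48 h (on this read-out higher numbers stand for weaker inhibition and lower numbers for stronger inhibition), compound 1 gives 960 nM, and compound 2 gives 750 nM. The two differ only by methoxy in place of hydrogen on an aromatic carbon, a change that gave a 1.3-fold lower number from compound 1 to compound 2 (0.11 log units; within the scatter).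

Compound 3 `C=C1CC[C@H]2[C@@](C)(CC[C@@H](O)[C@@]2(C)C(=O)NCc2ccccc2)[C@@H]1/C=C/C1=CCOC1=O` has a different core: it differs from compound 1 by benzylcarbamoyl in place of (benzylamino)methyl on a saturated ring carbon. In this assay compound 3 gives 19400 nM, which is a 20-fold higher number from compound 1 to compound 3 (1.31 log units; beyond the scatter).

Compound 4 `C=C1CC[C@H]2[C@@](C)(CC[C@@H](O)[C@@]2(C)C(=O)NCc2ccc(OC)cc2)[C@@H]1/C=C/C1=CCOC1=O` is made from compound 3 by methoxy in place of hydrogen on an aromatic carbon. Going by the values given here, this is the same change as the one from compound 1 to compound 2, and the place where it occurs is described in the same words for both pairs. Because the earlier step was a 1.3-fold lower number from compound 1 to compound 2 (0.11 log units; within the scatter), the expected step here is a 1.3-fold lower number from compound 3 to compound 4 (0.11 log units; within the scatter), a small one that stays within the range of repeated measurements. Accordingly the expected value for compound 4 in this assay is 15000 nM, estimated to fall between 6000 nM and 35000 nM.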

Compound 4, half-maximal inhibitory concentration: 6530 nM
Beside the measured number, compound 4's estimate is 2.3-fold (0.36 log units) above it; measured number inside the range.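

In this assay, methoxy in place of hydrogen on the aromatic ring gave a 3.0-fold lower number from compound 3 to compound 4 (0.47 log units; beyond the scatter), and set beside the same change on the core of compound 1, the two steps cannot be told apart: the same change on two cores in this assay, a 1.3-fold lower number (0.11 log units; within the scatter) from compound 1 to compound 2 and a 3.0-fold lower number (0.47 log units; beyond the scatter) from compound 3 to compound 4, 2.3-fold (0.37 log units) apart, within the scatter of two such steps. This shows that the size of the step seen on one core was a fair guide to the step on the other, even though only the new step lies beyond the scatter. It does not show a shared gain in inhibition, since the step on the core of compound 1 is too small to separate from repeat-measurement noise, and one pair per core cannot establish a rule for the series.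

Going by these compounds, it remains open whether another group at the same place on the aromatic ring, such as a chlorine atom or a dimethylamino group, would also carry from one core to the other. The same question stands for a longer chain, such as phenethyl, in place of the benzyl group.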